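Swapping 4-cyanobenzyl for 2-chlorobenzyl on the shared core

This account rests on a few compounds, and the source may have more. Where it says the series, first, only, none or still open, it means among the compounds named here.

Measured in a functional assay on HUVEC cells (Homo sapiens) for antiproliferative activity, read by MTT assay, with a stated time of 24 h; on this read-out higher numbers stand for weaker inhibition and lower numbers for stronger inhibition:
- compound 1 `COc1cc(OC)c(-c2coc3cc(OCc4ccccc4C)ccc3c2=O)cc1OC`: 4830 nM
- compound 2 `COc1cc(OC)c(-c2coc3cc(OCc4ccc(C#N)cc4)ccc3c2=O)cc1OC`: > 10000 nM (a limit of the assay, not a number)

Compound 2 stands at the limit of > 10000 nM in this assay, at which 1 of the 2 values shown sits. It therefore offers no number to start from. Compound 3 `COc1cc(OC)c(-c2coc3cc(OCc4ccccc4Cl)ccc3c2=O)cc1OC` differs from compound 2 as follows: 2-chlorophenyl in place of 4-cyanophenyl on a saturated chain carbon bound to an oxygen on an aromatic ring. In words, this is 2-chlorophenyl in place of 4-cyanophenyl on a saturated chain carbon bound to an oxygen on an aromatic ring.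

Among the compounds with values here, the only measured step bearing on this change is an at least 2.0-fold higher number from compound 1 to compound 2 (0.31 log units; beyond the scatter), which brought in the same 4-cyanophenyl in place of 2-methylphenyl. The change to compound 3 removes that group again, and 2-chlorophenyl takes the place that 2-methylphenyl holds in compound 1. The closest reference is thus compound 1 at 4830 nM.

A move to a lower number is therefore expected in this assay, with an estimated at least 2.2-fold lower number from compound 2 to compound 3 (0.34 log units; beyond the scatter). For compound 3 the expected value is 4500 nM, within an estimated range of 1800 nM to 11000 nM.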

Compound 3, half-maximal inhibitory concentration: > 10000 nM
Compound 3: no number, only a limit; the forecaster's own chance of this, stated with the estimate: 15%; middle value at least 2.2-fold (0.34 log units) away from the limit.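

In this assay compound 3 gives > 10000 nM, which is a limit of the assay and not a number. Chloro in place of methyl on an aromatic carbon produces an at least 2.0-fold higher number from compound 1 to compound 3 (0.31 log units; beyond the scatter), so 2-chlorophenyl does not stand in for the 2-methylphenyl of compound 1 in this series, and compound 1 remains the only one of the three with a number. The step between compound 2 and compound 3 cannot be read, and 4-cyanophenyl and 2-chlorophenyl on the saturated chain carbon end at the same assay limit: the limit of > 10000 nM in this assay, at which 2 of the 3 values shown sit.

As far as these compounds go, how compound 2 and compound 3 rank against each other remains open. So does whether an amine or a carboxylic acid in place of that methyl would give a lower number than compound 1 does.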